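Formyl in Place of Isopropyl: What to Expect for Compound 4

A few compounds are considered here, and "the series" means these few. Any claim that something is new, unique, unknown or untested is made for them only; others in the source may bear on it.

Among the measured compounds shown here, in a functional assay on the whole organism for inhibition, with Rattus norvegicus as the target, in the maximal electroshock model, at a dose of 25 mg/kg by the intraperitoneal route (on this read-out lower numbers stand for less inhibition and higher numbers for more inhibition at the one dose given (going by the name of the read-out)), compound 3 `CC(C)N(C)c1ncnc2c1ncn2Cc1ccccc1` gives 17%, the lowest of the three numbers measured so far. Compound 1 `C[C@H](c1ccccc1)n1cnc2c(N(C)C)ncnc21` gives 33% and compound 2 `C[C@@H](c1ccccc1)n1cnc2c(N(C)C)ncnc21` gives 33%; the step of no change at the digits printed from compound 1 to compound 2 (within the scatter) stays within the scatter, which fits with the fact that compounds 1 and 2 differ only in the configuration as drawn. Compound 4 `CN(C=O)c1ncnc2c1ncn2Cc1ccccc1` is compound 3 with formyl in place of isopropyl on a nitrogen on an aromatic ring. For the measured compounds named here, no measured step covers a change of this kind: the only step measured concerns configuration alone and gives no guide to the direction of this one. The expected step of a number 3 percentage points higher from compound 3 to compound 4 (within the scatter) is therefore small, with no clear direction beyond the scatter. For compound 4 the estimate is 20%, with a range from 5% to 40%.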

Compound 4, a percentage reported as inhibition, in the whole organism at one dose (the size of the read-out at that dose, not a potency): 0%
Compound 4: the middle estimate sits 20 percentage points above what was measured, and the stated range ends above it.
By their numbers in this assay, from the lowest: compound 4; then compound 3; then compounds 1 and 2 (each within the scatter of the next).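

Formyl in place of isopropyl on a nitrogen on an aromatic ring gives a number 17 percentage points lower from compound 3 to compound 4 (beyond the scatter) in this assay. Among the compounds shown here, the group at this position can therefore move the read-out, something the one earlier step, which concerned configuration alone, could not show. Nothing measured here explains why the number falls. Still open, as far as these compounds go, is whether ethyl or a longer chain at this position would keep the number of compound 3, and whether acetyl would behave as formyl does.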